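A few compounds are considered here, and "the series" means these few. Any claim that something is new, unique, unknown or untested is made for them only; others in the source may bear on it.

Of the compounds shown here, two with a shared core have been measured in an assay on isolated protein for binding affinity to adenosine receptor A1 (Bos taurus); on this read-out lower numbers stand for stronger inhibition and higher numbers for weaker inhibition. Compound 1 `CCCCCCNc1nc(-c2ccccc2)nc2c1nnn2Cc1ccccc1` carries a hexyl chain on the ring nitrogen and gives 13200000 nM in this assay. Compound 2 `OC1CCC(Nc2nc(-c3ccccc3)nc3c2nnn3Cc2ccccc2F)CC1` carries a hydroxylated cyclohexyl group and a fluorinated benzyl group and gives 1850000 nM in this assay. Compound 1 therefore stands at the higher of the two numbers, that is, the weaker end, with compound 2 beyond the usual scatter from it.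

Compound 3 `OCCCNc1nc(-c2ccccc2)nc2c1nnn2Cc1ccccc1` differs from compound 1 in one place: hydroxy in place of propyl on a saturated chain carbon, three bonds along the chain from a nitrogen on an aromatic ring. For the measured compounds named here, no measured pair isolates this particular change, so the size of its effect is open. Compound 2 shows that a hydroxylated group can sit on a compound with a lower number than compound 1, but that compound also differs in its benzyl group, so nothing can be attributed to the hydroxy alone.

The expected step is a 2.2-fold lower number from compound 1 to compound 3 (0.34 log units; beyond the scatter), a modest move toward a lower number that may not clear the scatter. Compound 3 is estimated at 6000000 nM in this assay, within a range from 1500000 nM to 25000000 nM.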

Compound 3, inhibition constant: 21400000 nM
For compound 3 the middle estimate is 3.6-fold (0.55 log units) below the measured one; the range from low to high includes it.
By their numbers in this assay, from the lowest: compound 2; then compounds 1 and 3 (each within the scatter of the next).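

In this assay, hydroxy in place of propyl on this chain gives a 1.6-fold higher number from compound 1 to compound 3 (0.21 log units; within the scatter), so the hexyl chain of compound 1 and the 3-hydroxypropyl chain of compound 3 cannot be told apart by this measurement. This is the only pair shown that isolates the change, and it shows that at this place, three bonds along the chain from a nitrogen on an aromatic ring, losing the propyl and adding a hydroxy leaves no effect that can be separated from the ordinary variation between repeat measurements. Nothing available here explains this outcome.

Still open, on these data alone, is whether hydroxy placed elsewhere on the chain, as in a 2-hydroxyethyl or hydroxymethyl chain, or a different end group such as an amine or a carboxylic acid, would move the number beyond the scatter. A single pair also cannot say whether the same change would behave alike on a compound with another group on the shared core, such as the fluorinated benzyl group of compound 2.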